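Ester analogues of a pyrazole core tested for cytotoxicity

The compounds below may be only part of what the source reports. "The series", "measured", "known", "first", "only" and "open" are said of these compounds alone.

Three esters built on a shared core were tested in a functional assay on HeLa cells (Homo sapiens) for cytotoxicity, read by MTT assay, with a stated time of 48 h; on this read-out lower numbers stand for stronger inhibition and higher numbers for weaker inhibition. Compound 1 `Cc1ccc(C(C)C)c(OC(=O)c2cn(-c3ccccc3)nc2-c2cccnc2)c1` carries a 2-isopropyl-5-methylphenyl group on the ester oxygen and a pyridin-3-yl group on the core. In this assay compound 1 gives > 100000 nM, which is a limit of the assay and not a number. Compound 2 `O=C(Oc1ccc2ccccc2c1)c1cn(-c2ccccc2)nc1-c1cccnc1` differs from it by naphthalen-2-yl in place of 2-isopropyl-5-methylphenyl on an oxygen next to a carbonyl group. In this assay compound 2 gives > 100000 nM, again a limit. Compound 3 `Cc1ccc(C(C)C)c(OC(=O)c2cn(-c3ccccc3)nc2-c2ccncc2)c1` differs from compound 1 by pyridin-4-yl in place of pyridin-3-yl on an aromatic carbon. In this assay compound 3 gives > 100000 nM, also a limit. The step that the two limits leave unreadable from compound 1 to compound 2 and the step that the two limits leave unreadable from compound 1 to compound 3 therefore cannot be sized, because of the limit of > 100000 nM in this assay, at which 3 of the 3 values shown sit.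

Compound 4 `O=C(Oc1ccc2ccccc2c1)c1cn(-c2ccccc2)nc1-c1ccncc1` has not yet been measured. It differs from compound 3 by naphthalen-2-yl in place of 2-isopropyl-5-methylphenyl on an oxygen next to a carbonyl group, and the place is word for word that of the change from compound 1 to compound 2, so this is the same change made a second time, now on the core of compound 3. Since both measured versions of the change sit at the limit, the step of a number no higher from compound 3 to compound 4 (the limit leaves the size open) is expected to be unreadable as well. Compound 4 is estimated to give 100000 nM, most likely reported as a limit, with a plausible range from 30000 nM to 300000 nM, resting on compound 3 at > 100000 nM and compound 2 at > 100000 nM.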

Compound 4, half-maximal inhibitory concentration: > 100000 nM
Compound 4 was reported as a limit; the forecaster's own chance of this, stated with the estimate: 85%; the middle value sits exactly at the limit.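

No new step can be read from compound 4 to compound 3 or to compound 2, because all four esters end at the same point: the limit of > 100000 nM in this assay, at which 4 of the 4 values shown sit.

The compounds shown leave open how strongly any of these four esters acts in this assay, and whether swapping 2-isopropyl-5-methylphenyl for naphthalen-2-yl, or pyridin-3-yl for pyridin-4-yl, changes that strength at all.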